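The compounds below may be only part of what the source reports. "The series", "measured", "known", "first", "only" and "open" are said of these compounds alone.

Compound 1 `CC1Oc2ccc(I)cc2C=C1[N+](=O)[O-]`: 36800 nM
Compound 2 `COC(=O)/C=C/c1ccc2c(c1)C=C([N+](=O)[O-])C(C(F)(F)F)O2`: 2570 nM

Of the compounds shown here, two have been measured in an assay on 1321N1 cells for antagonist activity at P2Y purinoceptor 6 (Homo sapiens), read by FLIPR and calcium flux; a lower number here means a stronger inhibitor, a higher number a weaker inhibitor. Compound 1 gives the highest of the two numbers; compound 2 sits a clear distance lower, beyond the usual scatter. The two share a core but differ in more than one place, so nothing is read into that gap beyond what the two values show.

Compound 3 `O=[N+]([O-])C1=Cc2cc(I)ccc2OC1C1CCC1` is not yet measured. It differs from compound 1 in one place: cyclobutyl in place of methyl on a saturated ring carbon. Going by the values given here, no measured pair shows this change, so the size of its step is open. Compound 3 is expected to land at 15000 nM, within 4000 nM to 50000 nM, a modest estimated shift a 2.5-fold lower number from compound 1 to compound 3 (0.39 log units; beyond the scatter) toward stronger inhibition, though one that might stay within the scatter.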

Compound 3, half-maximal inhibitory concentration: 33100 nM
Beside the measured number, compound 3's estimate is 2.2-fold (0.34 log units) below it; measured number inside the range.
By their numbers in this assay, from the lowest: compound 2; then compounds 3 and 1 (each within the scatter of the next).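

In this assay, cyclobutyl in place of methyl on the saturated ring carbon gives a 1.1-fold lower number from compound 1 to compound 3 (0.05 log units; within the scatter) and so lies within the scatter. This first step read at this position shows that a four-membered carbon ring can replace methyl here without a separation between the two values. No available evidence explains this result. The compounds shown leave open whether an amine or a carboxylic acid on this carbon would give a value apart from those of compound 1 and compound 3. They also leave open whether a longer chain would do so.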